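The source may hold more compounds than are shown below. What is called first, only, known or untested is meant among the compounds shown, and "the series" means these compounds.

Compound 2 `COc1cc(-c2ccc(C)n2-c2ccc(-c3nc4ccc(F)cc4s3)cc2)cc(OC)c1OC` is tested in a functional assay on MDA-MB-231 cells (Homo sapiens) for cytotoxicity, read by MTT assay, with a stated time of 72 h (on this read-out higher numbers stand for weaker inhibition and lower numbers for stronger inhibition), and gives 15400 nM. Its close relative compound 1 `COc1cc(-c2ccc(C)n2-c2ccc(-c3nc4ccccc4s3)cc2)cc(OC)c1OC` gives 16000 nM; the step of a 1.0-fold lower number from compound 1 to compound 2 (0.02 log units; within the scatter) sits within the scatter, so the two numbers tell the same story. Compound 3 `COc1ccc2nc(-c3ccc(-n4c(C)ccc4-c4cc(OC)c(OC)c(OC)c4)cc3)sc2c1` is not yet measured; it differs from compound 2 by methoxy in place of fluoro on an aromatic carbon. Among the measured compounds shown here, no measured step covers this exchange, and the one measured step on this ring, a 1.0-fold lower number from compound 1 to compound 2 (0.02 log units; within the scatter), was within the scatter. For compound 3 the step of a 1.0-fold lower number from compound 2 to compound 3 (0.01 log units; within the scatter) is therefore expected to stay within the scatter, and its estimated value is 15000 nM with a range from 7000 nM to 32000 nM.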

Compound 3, half-maximal inhibitory concentration: 12900 nM
The estimate for compound 3 lay 1.2-fold (0.07 log units) above the measured number; low and high end bracket the measured number.
By their numbers in this assay, from the lowest: compounds 3, 2 and 1 (each within the scatter of the next).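

Methoxy in place of fluoro on this aromatic carbon, the change from 6-fluoro-1,3-benzothiazol-2-yl to 6-methoxy-1,3-benzothiazol-2-yl, gives a 1.2-fold lower number from compound 2 to compound 3 (0.08 log units; within the scatter) in this assay. Methoxy in place of hydrogen gives a 1.2-fold lower number from compound 1 to compound 3 (0.09 log units; within the scatter), so hydrogen, fluoro and methoxy on this carbon now all read alike on this measure. Nothing available here offers an explanation for this.

Going by these compounds, whether an amine, a carboxylic acid or a longer chain such as butoxy on this carbon would move the number beyond the scatter stays open. So does whether a change elsewhere on the shared core would do so.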